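The source may report more compounds than this note shows. Statements on the series, on what has been measured and on what is new or still open speak of the compounds shown alone.

Measured compounds in the series:

compound 1 `CCc1ccc(-n2nc(-c3ccc(C(F)(F)F)cc3O)nc2-c2ccccc2O)cc1` — 64.4%
compound 2 `CC(C)(C)c1ccc(-n2nc(-c3ccc(C(F)(F)F)cc3O)nc2-c2ccccc2O)cc1` — 67.3%
compound 3 `Oc1cc(C(F)(F)F)ccc1-c1nc(-c2ccccc2O)n(-c2ccccc2Cl)n1` — 70.1%

In a functional assay on PC-12 cells (Rattus norvegicus) for cytotoxicity, read by MTT assay, with stated times of 2 h and 24 h, tested at 1 uM (a lower number here means a weaker effect, a higher number a stronger effect of the compound at the concentration tested), compound 3 gives the highest of the three numbers, but its separation from compound 2 and from compound 1 stays within the scatter of repeated measurements, so the three compounds cannot be placed in any order of effect. All three differ only in the group on the aromatic nitrogen of the shared core.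

Compound 4 `Cc1cc(C)cc(-n2nc(-c3ccc(C(F)(F)F)cc3O)nc2-c2ccccc2O)c1` has not yet been measured. The change is 3,5-dimethylphenyl in place of 2-chlorophenyl on an aromatic nitrogen. Among the measured compounds shown here, the steps that bear on it are the two earlier exchanges at the same position: a number 5.7 percentage points higher from compound 1 to compound 3 (within the scatter) and a number 2.8 percentage points higher from compound 2 to compound 3 (within the scatter). The exchange elsewhere, a number 2.9 percentage points higher from compound 1 to compound 2 (within the scatter), was of the same size. None of them moved the number beyond the scatter. For compound 4 a step of a number 3.1 percentage points lower from compound 3 to compound 4 (within the scatter) is therefore expected, not beyond the scatter. The estimate for compound 4 is 67%, with an expected range from 57% to 77%.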

Compound 4, a percentage reported as activity, at one concentration (the size of the read-out at that concentration, not a potency): 76.9%
Beside the measured number, compound 4's estimate is 9.9 percentage points below it, within the range that was stated.
By their numbers in this assay, from the lowest: compounds 1, 2, 3 and 4 (each within the scatter of the next, the first and the last beyond it).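

In this assay the exchange on the aromatic nitrogen gives its first step beyond the scatter: a number 12.5 percentage points higher from compound 1 to compound 4 (beyond the scatter) is a modest step, with 3,5-dimethylphenyl in place of 4-ethylphenyl. The other two steps to compound 4 stay within the scatter, since a number 6.8 percentage points higher from compound 3 to compound 4 (within the scatter) with 3,5-dimethylphenyl in place of 2-chlorophenyl and a number 9.6 percentage points higher from compound 2 to compound 4 (within the scatter) with 3,5-dimethylphenyl in place of 4-(tert-butyl)phenyl do not separate these pairs. This position can therefore carry a readable difference between substituted phenyl groups, but only compound 1 and compound 4 are separated.

Going by these compounds, it remains open whether a phenyl group bearing an amine or a carboxylic acid, or a longer alkyl chain in place of the phenyl group, would move the number further at this position. Nothing available explains the step between compound 1 and compound 4.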